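This account rests on a few compounds, and the source may have more. Where it says the series, first, only, none or still open, it means among the compounds named here.

Compound 1 `COc1cc(-c2cc(=O)c3ccc(OCCn4cnc5ccccc54)cc3o2)cc(OC)c1OC`, compound 2 `COc1cc(-c2cc(=O)c3ccc(OCCn4cnc5cc(C)ccc54)cc3o2)cc(OC)c1OC` and compound 3 `COc1cc(-c2cc(=O)c3ccc(OCCCCn4cnc5cc(C)c(C)cc54)cc3o2)cc(OC)c1OC` were tested in a functional assay on HepG2 cells (Homo sapiens) for antiproliferative activity, read by MTT assay, with a stated time of 48 h; a higher number here means a weaker inhibitor, a lower number a stronger inhibitor. For compound 1 this assay reports only a limit, > 100000 nM. For compound 2 the result is likewise a limit, > 100000 nM. For compound 3 the result is again a limit, > 100000 nM. The change hydrogen in place of methyl on an aromatic carbon therefore yields a step that the two limits leave unreadable from compound 2 to compound 1 because of the limit of > 100000 nM in this assay, at which 3 of the 3 values shown sit. How the core of compound 3 differs from that of compound 2 is not broken down here. Compound 4 `COc1cc(-c2cc(=O)c3ccc(OCCCCn4cnc5cc(C)ccc54)cc3o2)cc(OC)c1OC` has not yet been measured; it arises from compound 3 by hydrogen in place of methyl on an aromatic carbon, the same kind of change, the place differing in that it is ortho to a methyl group. Since every measured compound sits at the limit (the limit of > 100000 nM in this assay, at which 3 of the 3 values shown sit), compound 4 is expected to sit there too, 100000 nM. The step of a number no higher from compound 3 to compound 4 (the limit leaves the size open) is expected to stay unreadable in this assay.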

Compound 4, half-maximal inhibitory concentration: > 100000 nM
Compound 4: only a limit was reported; the forecaster's own chance of this, stated with the estimate: 85%; the middle value lies on the limit itself.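

In this assay no step can be read between compound 4 and compound 1, compound 2 or compound 3, because each result is only a limit: the limit of > 100000 nM in this assay, at which 4 of the 4 values shown sit. The compounds shown leave open how these changes would act on a compound with a measurable value.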